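Swapping methoxy for amino on a quinoline urea

The compounds below may be only part of what the source reports. "The series", "measured", "known", "first", "only" and "open" are said of these compounds alone.

Compound 1 `COc1ccc(NC(=O)Nc2cc(C)nc3ccccc23)cc1` is the most soluble of the three compounds measured in a physicochemical assay for solubility, at pH 7.4 (a lower number here means a less soluble compound, a higher number a more soluble compound), where compound 1 gives 19800 nM. The nearest of the others, compound 2 `COc1ccc(NC(=O)Nc2cc(C)nc3ccccc23)cc1F`, gives 2700 nM in this assay, and compound 3 `Cc1cc(NC(=O)Nc2cc(F)ccc2F)c2ccccc2n1` gives 500 nM. Among the measured compounds shown here, the single step between compounds that differ in one place, a 7.3-fold lower number from compound 1 to compound 2 (0.87 log units; beyond the scatter), concerns fluoro in place of hydrogen on an aromatic carbon and so does not touch the change considered here.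

Compound 4 `Cc1cc(NC(=O)Nc2ccc(N)cc2)c2ccccc2n1` differs from compound 1 in one place: amino in place of methoxy on an aromatic carbon. For the measured compounds named here, no measured pair shows amino in place of methoxy, so the expectation rests on the fact that the change keeps the same shared core and alters only the group on the six-membered aromatic ring of carbon only, para to a large group. The step is therefore expected to be small, perhaps within the scatter, and if anything upward: a 1.5-fold higher number from compound 1 to compound 4 (0.18 log units; within the scatter). Compound 4 is estimated to give 30000 nM in this assay, with a range from 10000 nM to 90000 nM.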

Compound 4, solubility: 18500 nM
Beside the measured number, compound 4's estimate is 1.6-fold (0.21 log units) above it; the range from low to high includes it.
By their numbers in this assay, from the lowest: compound 3; then compound 2; then compounds 4 and 1 (each within the scatter of the next).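

In this assay, amino in place of methoxy on an aromatic carbon para to a large group gives a 1.1-fold lower number from compound 1 to compound 4 (0.03 log units; within the scatter), so at this place the two groups cannot be told apart by this read-out. Among the compounds shown here, the only earlier step, a 7.3-fold lower number from compound 1 to compound 2 (0.87 log units; beyond the scatter), concerned fluoro in place of hydrogen, so this is the first reading of a change to the methoxy group itself, and it shows that this group can be exchanged for amino with no change beyond the scatter. Nothing measured here explains why the two groups read alike.

As far as these compounds go, it remains open whether a larger or differently charged group at this place, such as a carboxylic acid, a dimethylamino group or a longer ether chain, would also leave the number in place. From the compounds shown here alone, it is equally open whether the same exchange would read alike on compound 2, which carries the added fluoro.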